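Solubility notes: methylsulfonyl for trifluoromethyl on compound 3

The source may report more compounds than this note shows. Statements on the series, on what has been measured and on what is new or still open speak of the compounds shown alone.

Values so far in a physicochemical assay for solubility, read by nephelometry, in phosphate buffer, measured as kinetic solubility, with a stated time of 30 min, at pH 6.5; a higher number here means a more soluble compound, a lower number a less soluble compound
compound 1 `Cc1ccc(-c2cc(-c3ccc(S(C)(=O)=O)cc3)cnc2N)cc1C(F)(F)F` gives 1.6 ug/mL
compound 2 `CS(=O)(=O)c1ccc(-c2cnc(N)c(-c3ccc(C(F)(F)F)c(F)c3)c2)cc1` gives 1.6 ug/mL
compound 3 `CS(=O)(=O)c1ccc(-c2cnc(N)c(-c3ccc(C(F)(F)F)cc3)c2)cc1` gives < 1.6 ug/mL as a limit
compound 4 `CS(=O)(=O)c1ccc(-c2cnc(N)c(-c3ccc(S(C)(=O)=O)cc3)c2)cc1` is not yet measured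

Compound 3 stands only as a limit (< 1.6 ug/mL) and not as a number. That reading is the one case of the limit of < 1.6 ug/mL in this assay, at which 1 of the 3 values shown sits, in the set.

The next change puts methylsulfonyl in place of trifluoromethyl on an aromatic carbon para to a large group.

Among the measured compounds shown here, no measured step covers this exchange. For the measured compounds named here, the one step available is hydrogen in place of fluoro, a number no higher from compound 2 to compound 3 (the limit leaves the size open) and its size stays open. With compound 1 at 1.6 ug/mL and compound 2 at 1.6 ug/mL the series offers no higher reading, so the expectation stays close to these two values.

A small upward move is expected (an at least 1.5-fold higher number from compound 3 to compound 4 (0.19 log units; that floor lies within the scatter)) in this assay and a further limit reading remains quite possible. The estimate for compound 4 is 2.5 ug/mL (expected range 1.2 ug/mL to 10 ug/mL).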

Compound 4, solubility: 6.3 ug/mL
Compound 4: the middle estimate sits 2.5-fold (0.40 log units) below what was measured, and the stated range covers the measured number.
By their numbers in this assay, from the lowest: compounds 1 and 2 (each within the scatter of the next); then compound 4.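

In this assay, methylsulfonyl in place of trifluoromethyl on an aromatic carbon para to a large group gives an at least 3.9-fold higher number from compound 3 to compound 4 (0.59 log units; beyond the scatter). Among the compounds shown here, the earlier compounds held no methylsulfonyl at this position, and their one step could not be read, so this is the first step with a readable lower bound on its size. That size remains a floor because compound 3, with < 1.6 ug/mL, is a limit and not a number: the limit of < 1.6 ug/mL in this assay, at which 1 of the 4 values shown sits.

The compounds shown leave open how large the step truly is and whether the same exchange would carry over to another position or another substitution pattern on this ring. They also leave open whether an amine, a carboxylic acid or a nitrile at this position would read nearer compound 4 or nearer compound 3.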